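The compounds below may be only part of what the source reports. "The series", "measured", "known", "first", "only" and "open" are said of these compounds alone.

The measured compounds:
Compound 1, `O=c1c(OC/C(=N/O)c2ccccc2)c(-c2ccccc2)oc2ccccc12`: in a functional assay on SK-HEP1 cells (Homo sapiens) for antiproliferative activity (a lower number here means a stronger inhibitor of growth, a higher number a weaker inhibitor of growth), compound 1 gives 7210000 nM.
Compound 2, `O=c1c(OC/C(=N/O)c2ccc(F)cc2)c(-c2ccccc2)oc2ccccc12`: compound 2 gives 6900000 nM.
Compound 3, `CO/N=C(/COc1ccc2c(=O)cc(-c3ccccc3)oc2c1)c1ccccc1`: compound 3 gives 2000000 nM.

Compound 2 differs from compound 1 by fluoro in place of hydrogen on an aromatic carbon. Compound 4, `CO/N=C(/COc1ccc2c(=O)cc(-c3ccccc3)oc2c1)c1ccc(F)cc1`, is not yet measured and differs from compound 3 by fluoro in place of hydrogen on an aromatic carbon, the same change as that between compound 1 and compound 2, at a place described in the same words. How the core of compound 3 differs from the core of compound 1 is not broken down here; compound 3 shows the lowest of the three measured numbers, beyond the scatter from both others. Because the earlier change gave a 1.0-fold lower number from compound 1 to compound 2 (0.02 log units; within the scatter), the step from compound 3 to compound 4 is expected to be of similar size. The expected step is a 1.1-fold lower number from compound 3 to compound 4 (0.02 log units; within the scatter). Compound 4 is therefore expected to give about 1900000 nM, most likely between 900000 nM and 4000000 nM.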

Compound 4, concentration for 50% growth inhibition: 3300000 nM
Compound 4: the middle estimate sits 1.7-fold (0.24 log units) below what was measured, and the stated range covers the measured number.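

In this assay, putting fluoro in place of hydrogen gives a 1.7-fold higher number from compound 3 to compound 4 (0.22 log units; within the scatter), so compound 3 and compound 4 cannot be ranked. Set beside the earlier step, the change looks similar on both cores, and neither step stands out from the scatter: the same change on two cores in this assay, a 1.0-fold lower number (0.02 log units; within the scatter) from compound 1 to compound 2 and a 1.7-fold higher number (0.22 log units; within the scatter) from compound 3 to compound 4, 1.7-fold (0.24 log units) apart, within the scatter of two such steps. Within the data shown here, this shows that phenyl to 4-fluorophenyl made no clear difference on these two cores, but with only two pairs it does not show that the change would stay this small on other cores, and it does not explain the result.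

Still open, on these data alone, is whether an amine or a carboxylic acid in place of that hydrogen would shift growth inhibition beyond the scatter.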